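A few compounds are considered here, and "the series" means these few. Any claim that something is new, unique, unknown or untested is made for them only; others in the source may bear on it.

Series notes, a functional assay on MV4-11 cells (Homo sapiens) for antiproliferative activity, with a stated time of 6 days, tested at 6.25 uM; a lower number here means a weaker effect, a higher number a stronger effect of the compound at the concentration tested:
compound 1 `CNC(=O)N1CCCc2ccc(NC(=O)c3cccc(-c4ccn(C(C)=O)n4)c3)cc21` — 87.6%
compound 2 `CNC(=O)N1CCCc2ccc(NC(=O)c3ccc(-c4ccncc4)cc3)cc21` — 88.7%
compound 3 `CNC(=O)N1CCCc2ccc(NC(=O)c3cccc(-c4cc[nH]n4)c3)cc21` — 89.7%

Compound 2 gives the second highest of the three numbers. Its nearest neighbour on the numbers is compound 3 and its furthest is compound 1, and both gaps lie within the scatter, so the three values cannot be told apart on this data. Among the compounds with values here, the only step between measured compounds that differ in a single place is a number 2.1 percentage points higher from compound 1 to compound 3 (within the scatter), hydrogen in place of acetyl on an aromatic nitrogen, and it does not move the read-out beyond the scatter.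

Compound 4 `CNC(=O)N1CCCc2ccc(NC(=O)c3ccc(-c4cc[nH]n4)cc3)cc21` is not yet measured. It differs from compound 2 in one place: 1H-pyrazol-3-yl in place of pyridin-4-yl on an aromatic carbon. Within the data shown here, no measured pair shows this exact change. Among the measured compounds shown here, compound 3 carries the same 1H-pyrazol-3-yl group on the shared core, though at a different place on the ring, and its number and that of compound 2 lie within the scatter of each other, so pyridin-4-yl and 1H-pyrazol-3-yl give the same read-out so far. The step of a number 2.1 percentage points higher from compound 1 to compound 3 (within the scatter) likewise leaves the read-out where it is. On this basis the expected step for compound 4 is a number 0.7 percentage points lower from compound 2 to compound 4 (within the scatter), none beyond the scatter. Compound 4 is thus estimated at 88% in this assay, with a range from 80% to 94%.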

Compound 4, a percentage reported as inhibition, at one concentration (the size of the read-out at that concentration, not a potency): 99.1%
For compound 4 the middle estimate is 11.1 percentage points below the measured one, outside the stated range (above it).
By their numbers in this assay, from the lowest: compounds 1, 2, 3 and 4 (each within the scatter of the next, the first and the last beyond it).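

In this assay, within the data shown here, the aromatic carbon para to a large group gives the first step beyond the scatter (a number 10.4 percentage points higher from compound 2 to compound 4 (beyond the scatter)), modest in size, with 1H-pyrazol-3-yl in place of pyridin-4-yl. The earlier compounds shown here showed no step beyond the scatter, so the read-out does respond to the group held at this position, although this rests on a single pair at one tested concentration and says nothing about potency. The change alters ring size, the number of hetero atoms and the hydrogen-bond donor count together, and no information is available to explain the step or to separate these differences.

As far as these compounds go, it remains open whether a carboxylic acid or a simple amine at this position would give a read-out closer to that of compound 2 or compound 4. It is also open whether acetyl on the aromatic nitrogen of the pyrazole would keep the read-out of compound 4, since that group is shown only on compound 1, where the pyrazole sits at a different place on the ring.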